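A few compounds are considered here, and "the series" means these few. Any claim that something is new, unique, unknown or untested is made for them only; others in the source may bear on it.

Three sulfonamides of one shared core have been measured in a functional assay on ASPC1 cells (Homo sapiens) for inhibition, read by MTT assay, with a stated time of 72 h; on this read-out higher numbers stand for weaker inhibition of growth and lower numbers for stronger inhibition of growth. Compound 1 `O=S(=O)(NCCNCc1ccc(-c2ccccc2)cc1)c1cc(C(F)(F)F)cc(C(F)(F)F)c1` gives 2800 nM. Compound 2 `O=S(=O)(NCCCCNCc1ccc(Br)cc1)c1cc(C(F)(F)F)cc(C(F)(F)F)c1` gives 2900 nM. Compound 3 `O=S(=O)(NCCCNCc1ccc(Cl)c(Cl)c1)c1cc(C(F)(F)F)cc(C(F)(F)F)c1` gives 2800 nM. Within the data shown here, the only single-place step among them, a 1.0-fold lower number from compound 2 to compound 3 (0.02 log units; within the scatter), runs flat. Compound 3 thus stands level with compound 1 at the digits shown, the two together the lowest of the three numbers, and its gap to compound 2 is likewise within the scatter; nothing separates the three in this assay.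

Compound 4 `O=S(=O)(NCCCNCc1ccc(C(F)(F)F)cc1)c1cc(C(F)(F)F)cc(C(F)(F)F)c1` takes the next step from compound 3: 4-(trifluoromethyl)phenyl in place of 3,4-dichlorophenyl on a saturated chain carbon bound to an amine nitrogen. Among the measured compounds shown here, only the step from compound 2 to compound 3 bears on this change, since it also swaps the aryl group on the benzylamine; it was flat, and the comparison of compound 1 with compound 3, which differ in that same aryl group and in chain length, shows the same number for both. With every swap of that aryl group so far leaving the number unchanged, the step from compound 3 to compound 4 is expected to be no change at the digits printed from compound 3 to compound 4 (within the scatter), no shift beyond the scatter. Compound 4 is therefore estimated at 2800 nM in this assay, with a range from 1400 nM to 5600 nM.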

Compound 4, concentration for 50% growth inhibition: 2000 nM
The estimate for compound 4 lay 1.4-fold (0.15 log units) above the measured number, within the range that was stated.
By their numbers in this assay, from the lowest: compounds 4, 1, 3 and 2 (each within the scatter of the next).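

In this assay the swap of 3,4-dichlorophenyl for 4-(trifluoromethyl)phenyl, on a saturated chain carbon bound to an amine nitrogen, gives a 1.4-fold lower number from compound 3 to compound 4 (0.15 log units; within the scatter) and so adds a second flat step to the one earlier step among these compounds. What is new is that the chain stays the same here, so this result isolates a change of aryl group alone, and even a change from 8 to 10 heavy atoms, with both chlorine atoms replaced by a trifluoromethyl group, does not move the number beyond the scatter. No measurement that could account for this flat step is available.

The compounds shown leave open whether any other aryl group at this place would move the number beyond the scatter, for instance a 4-methoxyphenyl group, a 4-carboxyphenyl group or a pyridine ring in place of 4-(trifluoromethyl)phenyl. Also open, going by these compounds, is what an amide in place of the amine nitrogen, or a longer chain with the 4-(trifluoromethyl)benzyl group held constant, would do to the number in this assay on this shared core.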